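Fluorine Removal on Two Cores and Expected Cytotoxicity

The source may report more compounds than this note shows. Statements on the series, on what has been measured and on what is new or still open speak of the compounds shown alone.

The study compares four compounds. Compound 1 `Cc1cccc(N2CCN(CCCCNc3nc(NCc4ccco4)c4cc(F)ccc4n3)CC2)c1C` carries a fluoro group, while compound 2 `Cc1cccc(N2CCN(CCCCNc3nc(NCc4ccco4)c4ccccc4n3)CC2)c1C` has hydrogen in its place. In a functional assay on HCT-116 cells (Homo sapiens) for cytotoxicity, read by MTT assay, with a stated time of 2 days (a higher number here means a weaker inhibitor, a lower number a stronger inhibitor), compound 1 gives 820 nM, and compound 2 gives 840 nM, a step of a 1.0-fold higher number from compound 1 to compound 2 (0.01 log units; within the scatter) for the change (hydrogen in place of fluoro on an aromatic carbon). Compound 3 `CCN(CC)CCNc1nc(NCc2ccco2)c2cc(F)ccc2n1` is built on a different core; the difference between the two cores is not broken down here, and in this assay compound 3 gives "not determined" (no result reported). Compound 4 `CCN(CC)CCNc1nc(NCc2ccco2)c2ccccc2n1` differs from compound 3 by hydrogen in place of fluoro on an aromatic carbon, the same change as in the measured pair. With no number for compound 3, the expectation for compound 4 rests on the measured pair alone, whose step a 1.0-fold higher number from compound 1 to compound 2 (0.01 log units; within the scatter) lies within the scatter. Compound 4 is therefore expected near 1500 nM, with a wide range from 400 nM to 6000 nM.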

Compound 4, half-maximal inhibitory concentration: 25900 nM
Compound 4: the middle estimate sits 17-fold (1.24 log units) below what was measured; the measured number lies above the stated range.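

Among the compounds shown here, compound 3 gives "not determined" (no result reported), so no step from compound 3 to compound 4 can be read. The compounds shown leave open whether hydrogen in place of fluoro matters on the core of compound 3. No evidence given here bears on the result for compound 4.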